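Swapping Chloro for Azido on a Weaker Amide Isomer

The compounds below may be only part of what the source reports. "The series", "measured", "known", "first", "only" and "open" are said of these compounds alone.

Compound 1 `COc1ccc(N(Cc2cc(OC)c(OC)c(OC)c2)C(=O)CCl)cc1O` and compound 2 `COc1ccc(CN(C(=O)CCl)c2cc(OC)c(OC)c(OC)c2)cc1O` are built from the same atoms joined differently; the difference between the two cores is not broken down here. In a functional assay on MGC-803 cells (Homo sapiens) for inhibition, read by MTT assay, with a stated time of 48 h (on this read-out higher numbers stand for weaker inhibition and lower numbers for stronger inhibition), compound 1 gives 24500 nM, while compound 2 gives 84 nM. Compound 3 `COc1ccc(CN(C(=O)CN=[N+]=[N-])c2cc(OC)c(OC)c(OC)c2)cc1O` carries the change azido in place of chloro on a saturated chain carbon bound to a carbonyl carbon on the core of compound 2. In this assay compound 3 gives 120 nM, a step of a 1.4-fold higher number from compound 2 to compound 3 (0.15 log units; within the scatter). Compound 4 `COc1ccc(N(Cc2cc(OC)c(OC)c(OC)c2)C(=O)CN=[N+]=[N-])cc1O` carries the same change, (azido in place of chloro on a saturated chain carbon bound to a carbonyl carbon), on the core of compound 1. Because the step of a 1.4-fold higher number from compound 2 to compound 3 (0.15 log units; within the scatter) stayed within the scatter, compound 4 is expected to shift by about a 1.3-fold higher number from compound 1 to compound 4 (0.12 log units; within the scatter), an expectation that rests only on that one parallel pair. Compound 4 is therefore estimated at 32000 nM, most likely between 12000 nM and 85000 nM.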

Compound 4, half-maximal inhibitory concentration: 22400 nM
Estimate against measurement, compound 4: 1.4-fold (0.15 log units) above; measured number inside the range.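

The swap of chloro for azido on a saturated chain carbon bound to a carbonyl carbon again gives only a small step, a 1.1-fold lower number from compound 1 to compound 4 (0.04 log units; within the scatter). In this assay, the two cores therefore respond alike to this change, and the step seen on one core carried over to the other: the same change on two cores in this assay, a 1.4-fold higher number (0.15 log units; within the scatter) from compound 2 to compound 3 and a 1.1-fold lower number (0.04 log units; within the scatter) from compound 1 to compound 4, 1.6-fold (0.19 log units) apart, within the scatter of two such steps. This rests on just two pairs and on a change that barely moved the number on either core, so it does not show that a change with a large step would carry over in the same way.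

The compounds shown leave open how an amine or a longer chain in place of chloro would behave on either core. They also leave open which feature of the two cores sets them so far apart.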